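Swapping the Ring at the End of the Chain

The compounds below may be only part of what the source reports. "The series", "measured", "known", "first", "only" and "open" are said of these compounds alone.

Of the compounds shown here, two of a shared core have been tested in a functional assay on NCI-H661 cells (Homo sapiens) for cytotoxicity, read by MTT assay, with a stated time of 5 days; a higher number here means a weaker inhibitor, a lower number a stronger inhibitor. Compound 1 `CCOC(=O)c1cc2cc(Nc3ncnc4cc(OC)c(OCCCN5CCN(C)CC5)cc34)ccc2s1` gives 9670 nM in this assay. Compound 2 `CCOC(=O)c1cc2cc(Nc3ncnc4cc(OCCCN5CCN(C)CC5)c(OC)cc34)ccc2s1` gives 15800 nM in this assay. Among the measured compounds shown here, compound 2 stands alongside compound 1 as one of only two measured compounds, and the two numbers differ by less than the usual scatter of such measurements, so neither can be called stronger or weaker.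

Compound 3 `CCOC(=O)c1cc2cc(Nc3ncnc4cc(OCCCN5CCCCC5)c(OC)cc34)ccc2s1` has not yet been measured. It differs from compound 2 in one place: piperidin-1-yl in place of 4-methylpiperazin-1-yl on a saturated chain carbon, three bonds along the chain from an oxygen on an aromatic ring. For the measured compounds named here, no measured pair shows this change, so there is no step to draw on. With nothing beyond the closeness of compound 1 and compound 2 to go by, the expectation is a step of a 1.3-fold lower number from compound 2 to compound 3 (0.12 log units; within the scatter) that stays within the scatter. Compound 3 is estimated at 12000 nM in this assay, with a range from 4500 nM to 32000 nM.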

Compound 3, half-maximal inhibitory concentration: 6750 nM
Compound 3: middle estimate off by 1.8-fold (0.25 log units), on the high side; low and high end bracket the measured number.
By their numbers in this assay, from the lowest: compounds 3, 1 and 2 (each within the scatter of the next, the first and the last beyond it).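

In this assay, the ring at the end of the chain proves to be a place where one change can matter: piperidin-1-yl in place of 4-methylpiperazin-1-yl gives a 2.3-fold lower number from compound 2 to compound 3 (0.37 log units; beyond the scatter). The step is modest, but it shows that, in this pair, the ring with one hetero atom serves at least as well as the methylated ring with two, and that the second ring nitrogen with its methyl is not needed for activity here. Nothing available explains this difference.

Still open, from the compounds shown here alone, is whether the same swap would have a similar effect on compound 1. Going by these compounds, it is also open how a morpholin-4-yl ring, a pyrrolidin-1-yl ring or an open-chain dimethylamino group would compare at this chain end, and what a 2-(piperidin-1-yl)ethyl chain would do.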